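The source may report more compounds than this note shows. Statements on the series, on what has been measured and on what is new or still open speak of the compounds shown alone.

Of the compounds shown here, three sharing one core have been measured in an assay on membranes from HeLa cells for displacement of a labelled ligand from adenosine receptor A3 (Homo sapiens), read by scintillation counting, with a stated time of 180 min, tested at 1 uM; on this read-out higher numbers stand for more inhibition at the one concentration tested (going by the name of the read-out) and lower numbers for less inhibition. Compound 1 `CCCOC(=O)C1=C(C)NC(=O)NC1c1ccoc1` gives 11%. Compound 2 `CCSC(=O)C1=C(C)NC(=O)NC1c1ccoc1` gives 1%. Compound 3 `CC1=C(C(=O)OC2CCC2)C(c2ccoc2)NC(=O)N1` gives 1%. Compound 3 thus stands level with compound 2 at the digits shown, the two together the lowest of the three numbers, while compound 1 sits higher by an amount that the repeat-to-repeat spread of this kind of measurement easily covers; none of the three is separated from the others beyond that spread.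

Compound 4 `CC1=C(C(=O)OCC2CC2)C(c2ccoc2)NC(=O)N1` has not yet been measured. Its difference from compound 3 is cyclopropylmethyl in place of cyclobutyl on an oxygen next to a carbonyl group.

Of the measured steps, the one that bears most closely on this change is the exchange of the group on the same oxygen: a number 10 percentage points lower from compound 1 to compound 3 (within the scatter). The exchange of the group on the carbonyl carbon, no change at the digits printed from compound 2 to compound 3 (within the scatter), and the wider change a number 10 percentage points lower from compound 1 to compound 2 (within the scatter) likewise stayed within the spread. Every change seen so far, including one at the very position now altered, has left the read-out where it was, so compound 4 is expected to show a number 2 percentage points higher from compound 3 to compound 4 (within the scatter), nothing beyond the scatter. The estimate for compound 4 is 3%, with a range from -6% to 14%.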

Compound 4, a percentage reported as inhibition, at one concentration (the size of the read-out at that concentration, not a potency): 3%
Estimate against measurement, compound 4: no gap at the digits printed; low and high end bracket the measured number.
By their numbers in this assay, from the lowest: compounds 2, 3, 4 and 1 (each within the scatter of the next).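

In this assay, putting cyclopropylmethyl in place of cyclobutyl on an oxygen next to a carbonyl group gives a number 2 percentage points higher from compound 3 to compound 4 (within the scatter) and so shows that exchanging a four-membered carbon ring for a three-membered one, with the heavy-atom count unchanged, leaves the read-out within its usual spread. The comparisons with the other two compounds agree: cyclopropylmethoxy in place of ethylsulfanyl on a carbonyl carbon gives a number 2 percentage points higher from compound 2 to compound 4 (within the scatter) and cyclopropyl in place of ethyl on a saturated chain carbon bound to an oxygen next to a carbonyl group gives a number 8 percentage points lower from compound 1 to compound 4 (within the scatter) so with this fourth compound, still no change at this place separates any two compounds beyond the scatter. No other measurement bears on this result, so nothing can be said about what lies behind it.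

Because each compound was tested at only one concentration, these numbers say nothing about potency. A longer chain such as octyl or a benzyl group on the same oxygen, or an amine in place of that oxygen on the carbonyl carbon, could test whether any group at this place moves the read-out beyond the scatter.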